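Benzyl sulfanyl variation on a shared core

The compounds below may be only part of what the source reports. "The series", "measured", "known", "first", "only" and "open" are said of these compounds alone.

Compound 1 `Cc1cc(Nc2cc(-c3ccccc3)[nH]n2)n2nc(SCc3ccc(F)cc3)nc2n1` is the reference point. In a functional assay on MCF7 cells (Homo sapiens) for inhibition, read by MTT assay, with a stated time of 72 h (a lower number here means a stronger inhibitor, a higher number a weaker inhibitor), compound 1 gives 4020 nM, the second highest of three numbers, with all three lying within the scatter of one another. Compound 2 `Cc1cc(Nc2cc(-c3ccccc3)[nH]n2)n2nc(SCc3c(Cl)cccc3Cl)nc2n1` gives 3230 nM, and compound 3 `Cc1cc(Nc2cc(-c3ccccc3)[nH]n2)n2nc(SCc3ccc(C(F)(F)F)cc3)nc2n1` gives 4820 nM. Both measured steps exchange the aryl group on the saturated chain carbon bound to a sulfur, and neither moves beyond the scatter: a 1.2-fold lower number from compound 1 to compound 2 (0.10 log units; within the scatter) and a 1.2-fold higher number from compound 1 to compound 3 (0.08 log units; within the scatter). Compound 4 `COc1ccc(CSc2nc3nc(C)cc(Nc4cc(-c5ccccc5)[nH]n4)n3n2)cc1` carries the change methoxy in place of fluoro on an aromatic carbon at that same place. With three aryl variations there all flat, for compound 4 no step beyond the scatter is expected, a 1.0-fold lower number from compound 1 to compound 4 (0.00 log units; within the scatter). Compound 4 is estimated at 4000 nM, with a range of 2000 nM to 8000 nM.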

Compound 4, half-maximal inhibitory concentration: 4020 nM
Compound 4: middle estimate off by 1.0-fold (0.00 log units), on the low side; low and high end bracket the measured number.
By their numbers in this assay, from the lowest: compounds 2, 1, 4 and 3 (each within the scatter of the next).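

In this assay, methoxy brings a hydrogen-bond acceptor that fluoro lacks, yet this place on the aromatic ring shows (no change at the digits printed from compound 1 to compound 4 (within the scatter)). The two other steps stay flat as well (a 1.2-fold lower number from compound 3 to compound 4 (0.08 log units; within the scatter); a 1.2-fold higher number from compound 2 to compound 4 (0.10 log units; within the scatter)), so an oxygen-linked group at this place joins the halogen-bearing aryl variations without separating from them. No measured evidence bears on this flatness. Still open, on these data alone, is whether an amine or a carboxylic acid on this aromatic ring, or a longer chain in place of the benzyl group, would move the number beyond the scatter.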